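Replacing the chloromethyl amide with a methoxyphenyl amide

A few compounds are considered here, and "the series" means these few. Any claim that something is new, unique, unknown or untested is made for them only; others in the source may bear on it.

Of the compounds shown here, three sharing one core have been measured in a functional assay on MCF7 cells (Homo sapiens) for cytotoxicity, read by MTT assay, with a stated time of 48 h; on this read-out lower numbers stand for stronger inhibition and higher numbers for weaker inhibition. Compound 1 `O=C(CSc1nc2ccc(NC(=O)c3ccc(Cl)cc3)cc2s1)NCc1ccc(Cl)cc1` gives 29300 nM, and compound 2 `O=C(CSc1nc2ccc(NC(=O)c3ccccc3)cc2s1)NCc1ccc(Cl)cc1` gives 33700 nM, a pair separated only by a 1.2-fold higher number from compound 1 to compound 2 (0.06 log units; within the scatter). Compound 3 `O=C(CSc1nc2ccc(NC(=O)CCl)cc2s1)NCc1ccc(Cl)cc1` gives 4900 nM, the lowest of the three numbers, and its nearest neighbour is compound 1, while compound 2 stands furthest away.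

Compound 4 `COc1ccccc1C(=O)Nc1ccc2nc(SCC(=O)NCc3ccc(Cl)cc3)sc2c1` differs from compound 3 by 2-methoxyphenyl in place of chloromethyl on a carbonyl carbon. The two measured steps that bear on this change both run the opposite way, from an aryl group to chloromethyl: a 6.0-fold lower number from compound 1 to compound 3 (0.78 log units; beyond the scatter) and a 6.9-fold lower number from compound 2 to compound 3 (0.84 log units; beyond the scatter). Reversing that direction, an aryl group entering in place of chloromethyl is expected to give a clearly higher number in this assay , roughly undoing the gain seen in compound 3.

Compound 4 is therefore estimated at 30000 nM, within a range of 12000 nM to 75000 nM, a step of a 6.1-fold higher number from compound 3 to compound 4 (0.79 log units; beyond the scatter) that is expected to land near the numbers of compound 1 and compound 2.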

Compound 4, half-maximal inhibitory concentration: 1100 nM
Beside the measured number, compound 4's estimate is 27-fold (1.44 log units) above it; measured number below the stated range.
By their numbers in this assay, from the lowest: compound 4; then compound 3; then compounds 1 and 2 (each within the scatter of the next).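

In this assay, the aryl amide is not tied to the weaker numbers, as compounds 1 and 2 had suggested: an aryl group in place of chloromethyl can also lower the number, with 2-methoxyphenyl giving a 4.5-fold lower number from compound 3 to compound 4 (0.65 log units; beyond the scatter). The substituent on the ring therefore matters a great deal, since methoxy in place of hydrogen on an aromatic carbon gives a 31-fold lower number from compound 2 to compound 4 (1.49 log units; beyond the scatter), and 2-methoxyphenyl in place of 4-chlorophenyl gives a 27-fold lower number from compound 1 to compound 4 (1.43 log units; beyond the scatter), whereas chloro in place of hydrogen had left the number within the scatter. No measurement at hand explains why methoxy has so much larger a step than chloro.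

From the compounds shown here alone, it remains open whether a hydroxy group, an ethoxy group or an amine on the same ring would give a comparable step. The compounds shown also leave open whether the step from compound 2 would hold on a core carrying a different group in place of the 4-chlorobenzyl amide.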